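Boc protection of the amine in a lipophilic glycine series

The compounds below may be only part of what the source reports. "The series", "measured", "known", "first", "only" and "open" are said of these compounds alone.

Compound 1 `CCCCCCCCCCCCCCC(N)CNCC(=O)O`: 31000 nM
Compound 2 `CCCCCCCCCCCCCCC(CNCC(=O)OCC)NC(=O)OC(C)(C)C`: 28000 nM
Compound 3 `CCCCCCCCCCCCCCC(N)CN(CC(=O)OCC)CC(=O)OCC`: 32000 nM

In a functional assay on Jurkat cells (Homo sapiens) for inhibition (a higher number here means a weaker inhibitor, a lower number a stronger inhibitor), compound 3 has the highest of the three numbers, but its gaps to compound 1 and to compound 2 both lie within the scatter, so the three compounds cannot be ordered. Compound 4 `CCCCCCCCCCCCCCC(CN(CC(=O)OCC)CC(=O)OCC)NC(=O)OC(C)(C)C` differs from compound 3 by tert-butoxycarbonyl in place of hydrogen on an amine nitrogen. Compound 2, which also carries a tert-butoxycarbonyl on its amine, sits at the same level as the free amines, so no step beyond the scatter is expected here in either direction. Compound 4 is therefore estimated at 30000 nM, between 12000 nM and 80000 nM, a step of a 1.1-fold lower number from compound 3 to compound 4 (0.03 log units; within the scatter) that is expected to stay inside the usual scatter.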

Compound 4, half-maximal inhibitory concentration: > 60000 nM
Compound 4: only a limit was reported; the forecaster's own chance of this, stated with the estimate: 20%; middle value at least 2.0-fold (0.30 log units) away from the limit.
By their numbers in this assay, from the lowest: compounds 2, 1 and 3 (each within the scatter of the next). At a limit, above all of these: compound 4.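

In this assay compound 4 is reported only as a limit: the limit of > 60000 nM in this assay, at which 1 of the 4 values shown sits.

Tert-butoxycarbonyl in place of hydrogen on the amine nitrogen gives an at least 1.8-fold higher number from compound 3 to compound 4 (0.27 log units; that floor lies within the scatter), so this change is not shown to matter on its own. For the compounds shown here, with tert-butoxycarbonyl already present, (ethoxycarbonyl)methyl in place of hydrogen on an amine nitrogen gives an at least 2.1-fold higher number from compound 2 to compound 4 (0.33 log units; beyond the scatter), the first step in this set to pass the scatter, and it points towards weaker inhibition.

On these data alone, how far compound 4 lies past its limit remains open. So does whether an acetyl group on the amine, or free carboxylic acids in place of the ethyl esters, would give the same result.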